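Fluoro for hydrogen on the pendant phenyl of compound 3

A few compounds are considered here, and "the series" means these few. Any claim that something is new, unique, unknown or untested is made for them only; others in the source may bear on it.

Compound 1 `COc1cc(-n2cnc3ccc(-c4ccc(C(C)=O)cc4)cc32)cc(OC)c1OC`: in a functional assay on SGC-7901 cells (Homo sapiens) for antiproliferative activity, read by MTT assay, with a stated time of 72 h (on this read-out lower numbers stand for stronger inhibition and higher numbers for weaker inhibition), compound 1 gives 450 nM.
Compound 2 `COc1ccc(-c2ccc3ncn(-c4cc(OC)c(OC)c(OC)c4)c3c2)cc1O`: in this assay compound 2 gives 44 nM.
Compound 3 `COc1cc(-n2cnc3ccc(-c4ccccc4)cc32)cc(OC)c1OC`: in this assay compound 3 gives 290 nM.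

Compound 3 holds the second highest number of the three. Compound 1 sits within the scatter of it, as a 1.6-fold lower number from compound 1 to compound 3 (0.19 log units; within the scatter) shows, while compound 2 stands apart, as a 6.6-fold higher number from compound 2 to compound 3 (0.82 log units; beyond the scatter) shows. Compound 4 `COc1cc(-n2cnc3ccc(-c4ccc(F)cc4)cc32)cc(OC)c1OC` differs from compound 3 by fluoro in place of hydrogen on an aromatic carbon. Going by the values given here, the one measured step at this carbon, a 1.6-fold lower number from compound 1 to compound 3 (0.19 log units; within the scatter), stayed within the scatter; the beyond-scatter step a 6.6-fold higher number from compound 2 to compound 3 (0.82 log units; beyond the scatter) came from exchanging the whole attached ring. Fluoro for hydrogen is a smaller change than either, so a step within the scatter is expected, a 1.2-fold lower number from compound 3 to compound 4 (0.06 log units; within the scatter), with no firm direction. Compound 4 is therefore estimated at 250 nM, within a range from 120 nM to 600 nM.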

Compound 4, half-maximal inhibitory concentration: 3500 nM
Compound 4: middle estimate off by 14-fold (1.15 log units), on the low side; the whole stated range lies below it.
By their numbers in this assay, from the lowest: compound 2; then compounds 3 and 1 (each within the scatter of the next); then compound 4.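

On the pendant ring, the carbon para to a large group proves sensitive to a single atom: in this assay, fluoro in place of hydrogen gives a 12-fold higher number from compound 3 to compound 4 (1.08 log units; beyond the scatter), although acetyl at that carbon stayed within the scatter of hydrogen. The fluoro compound also separates from the acetyl and 3-hydroxy-4-methoxyphenyl analogues, with a 7.8-fold higher number from compound 1 to compound 4 (0.89 log units; beyond the scatter) and an 80-fold higher number from compound 2 to compound 4 (1.90 log units; beyond the scatter), making it the weakest of the four. No measured evidence bears on this loss. On these data alone, whether it is specific to fluoro remains open. Chloro or an amine at this carbon would test that.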